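The source may hold more compounds than are shown below. What is called first, only, known or untested is meant among the compounds shown, and "the series" means these compounds.

Three compounds with measured values and one without all carry a sulfonyl sulfur whose other neighbour is an aromatic carbon. Compound 1 `N#Cc1cccc(S(=O)(=O)c2cnc3cc(F)ccc3c2-c2cccc(Cl)c2)c1` and compound 2 `O=S(=O)(c1cc(Cl)cc(Cl)c1)c1cnc2cc(F)ccc2c1-c1cccc(Cl)c1` share one core, while compound 3 `N#Cc1cccc(S(=O)(=O)c2cnc3c(F)cccc3c2-c2ccc(Cl)cc2)c1` and compound 4 `O=S(=O)(c1cc(Cl)cc(Cl)c1)c1cnc2c(F)cccc2c1-c1ccc(Cl)cc1` share another; the difference between the two cores is not broken down here. In an ADME assay on microsomes from liver (Homo sapiens) for metabolic stability, tested at 2.5 uM (on this read-out higher numbers stand for fast clearance and lower numbers for slow clearance), compound 1 gives 0.99 mL/min. Compound 2 gives 0.93 mL/min in this assay. The change between them, (3,5-dichlorophenyl in place of 3-cyanophenyl on a sulfonyl sulfur), made a step of a 1.1-fold lower number from compound 1 to compound 2 (0.03 log units; within the scatter). Compound 3 gives 0.08 mL/min in this assay, the lowest of the three numbers, and both other compounds stand beyond the scatter from it. The same change, (3,5-dichlorophenyl in place of 3-cyanophenyl on a sulfonyl sulfur), leads from compound 3 to compound 4, and the place is the same word for word. Since the earlier step of a 1.1-fold lower number from compound 1 to compound 2 (0.03 log units; within the scatter) stayed within the scatter, a step of about the same size, a 1.1-fold higher number from compound 3 to compound 4 (0.05 log units; within the scatter), is expected here, resting on that single example. Compound 4 is therefore expected to give about 0.09 mL/min, between 0.04 mL/min and 0.2 mL/min.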

Compound 4, intrinsic clearance in a liver preparation (reported as CLH), per the amount of preparation that the assay uses: 0.78 mL/min
For compound 4 the middle estimate is 8.7-fold (0.94 log units) below the measured one; the measured number lies above the stated range.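

In this assay, putting 3,5-dichlorophenyl in place of 3-cyanophenyl on a sulfonyl sulfur gave a 9.8-fold higher number from compound 3 to compound 4 (0.99 log units; beyond the scatter). Set beside the earlier step, the size of this change depends on the core that carries it: the same change on two cores in this assay, a 1.1-fold lower number (0.03 log units; within the scatter) from compound 1 to compound 2 and a 9.8-fold higher number (0.99 log units; beyond the scatter) from compound 3 to compound 4, 10-fold (1.02 log units) apart, beyond the scatter of two such steps

With one pair on each core, this shows that a step read on one core cannot simply be copied onto the other, even when the swapped groups and their place are identical. It does not show which feature of the cores lies behind the gap, or how the change would behave on a third core.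

The compounds shown carry only 3-cyanophenyl and 3,5-dichlorophenyl on the sulfonyl sulfur, so it stays open how a phenyl ring bearing an amine or a carboxylic acid there would read on either core. Also open, going by these compounds, is which part of the difference between the two cores goes with the gap, a question for compounds whose cores differ in one place only.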